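Moving a hydroxyl on a tri-aryl pyridine core

The source may hold more compounds than are shown below. What is called first, only, known or untested is meant among the compounds shown, and "the series" means these compounds.

Measured compounds:
compound 1, `Oc1cccc(-c2cc(-c3cccc(O)c3)nc(-c3ccccc3O)c2)c1`, > 50000 nM
compound 2, `Oc1ccc(-c2cc(-c3ccc(O)cc3)nc(-c3cccc(O)c3)c2)cc1`, 5800 nM
compound 3, `Oc1ccc(-c2cc(-c3ccccc3O)nc(-c3ccccc3O)c2)cc1`, > 50000 nM

All three share a core bearing three hydroxyphenyl groups, and differ only in where the hydroxyl sits on each of those rings. Within the data shown here, in a functional assay on DU-145 cells (Homo sapiens) for cytotoxicity, read by CCK-8 assay, with a stated time of 4 days (a lower number here means a stronger inhibitor, a higher number a weaker inhibitor), compound 2 gives 5800 nM, the only numerical value so far. Compound 3 sits at the limit of > 50000 nM in this assay, at which 2 of the 3 values shown sit, so for compound 3 only a limit is known, not a number. Compound 1 likewise gives only a limit, > 50000 nM.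

Compound 4, `Oc1ccc(-c2cc(-c3cccc(O)c3)nc(-c3ccccc3O)c2)cc1`, has not yet been measured. It differs from compound 3 by 3-hydroxyphenyl in place of 2-hydroxyphenyl on an aromatic carbon. Compound 3 carries two 2-hydroxyphenyl groups; compound 4 keeps one of them and gains a 3-hydroxyphenyl group, so its pattern of hydroxyls moves partway toward that of compound 2.

Because compound 2, which has no 2-hydroxyphenyl group, shows 5800 nM, a move toward stronger inhibition seems possible. The 2-hydroxyphenyl group that compound 4 keeps is also present in compound 1, and compound 1 gives only a limit, > 50000 nM, which argues for caution. Compound 4 is estimated at 25000 nM, between 6000 nM and 100000 nM, so the expected step of an at least 2.0-fold lower number from compound 3 to compound 4 (0.30 log units; that floor lies within the scatter) would run toward stronger inhibition, beyond the scatter but with a real chance that only a limit is reported again.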

Compound 4, half-maximal inhibitory concentration: 3420 nM
The estimate for compound 4 lay 7.3-fold (0.86 log units) above the measured number; the whole stated range lies above it.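

In this assay, 3-hydroxyphenyl in place of 2-hydroxyphenyl on the aromatic carbon next to the ring nitrogen gives an at least 14-fold lower number from compound 3 to compound 4 (1.16 log units; beyond the scatter), the first sign that moving a single hydroxyl on this ring can by itself carry a large change. Against compound 2 the picture differs: 2-hydroxyphenyl in place of 4-hydroxyphenyl gives a 1.7-fold lower number from compound 2 to compound 4 (0.23 log units; within the scatter), so one 2-hydroxyphenyl group does not by itself bring a compound to the limit, even though compound 1 also carries one and stays there. The third step, 4-hydroxyphenyl in place of 3-hydroxyphenyl, gives an at least 14-fold lower number from compound 1 to compound 4 (1.16 log units; beyond the scatter), which shows that the hydroxyl's place on another ring counts as well, and this step and the first both start from a limit rather than a number: the limit of > 50000 nM in this assay, at which 2 of the 4 values shown sit.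

Going by these compounds, the true sizes of those two large steps stay unknown until compound 1 and compound 3 have numbers instead of limits. All the compounds shown carry hydroxyl groups, so it remains open whether a methoxy group, an amine or a plain phenyl ring at these places would keep the effect.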